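The source may report more compounds than this note shows. Statements on the series, on what has been measured and on what is new or still open speak of the compounds shown alone.

Measured so far in a functional assay on isolated protein for inhibition of Glucose-dependent insulinotropic receptor (Rattus norvegicus), read by HTRF and cAMP accumulation; on this read-out higher numbers stand for an effect only at larger amounts of compound and lower numbers for an effect already at smaller amounts: compound 1 `Cc1nc(S(C)(=O)=O)ccc1Oc1ncnc(OC2CCN(C(=O)OC(C)C)CC2)c1F` gives 142 nM; compound 2 `Cc1nc(S(C)(=O)=O)ccc1Oc1ncnc(OC2CCN(C(=O)OC(C)(C)CF)CC2)c1F` gives 138 nM; compound 3 `Cc1nc(S(C)(=O)=O)ccc1Oc1ncnc(OC2CCN(C(=O)SC3CC3)CC2)c1F` gives 126 nM.

Compound 3 shows the smallest of the three numbers, but the gaps are slight: a 1.1-fold lower number from compound 1 to compound 3 (0.05 log units; within the scatter) and a 1.1-fold lower number from compound 2 to compound 3 (0.04 log units; within the scatter), so the three compounds are not separated. Compound 4 `Cc1nc(S(C)(=O)=O)ccc1Oc1ncnc(OC2CCN(C(=O)SC3(C)CC3)CC2)c1F` differs from compound 3 by methyl in place of hydrogen on a saturated ring carbon. For the measured compounds named here, no measured pair changes this ring directly; the nearest information is the replacement that built the cyclopropyl thiocarbamate, which in a 1.1-fold lower number from compound 1 to compound 3 (0.05 log units; within the scatter) and a 1.1-fold lower number from compound 2 to compound 3 (0.04 log units; within the scatter) left this assay essentially unchanged, as did the small added group in a 1.0-fold lower number from compound 1 to compound 2 (0.01 log units; within the scatter). Changes around this carbonyl side chain have so far stayed within the scatter, so no step beyond the scatter is expected here either. For compound 4 this estimate amounts to a 1.0-fold higher number from compound 3 to compound 4 (0.01 log units; within the scatter). Compound 4 is thus expected near 130 nM, within 65 nM to 260 nM.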

Compound 4, half-maximal effective concentration: 166 nM
Beside the measured number, compound 4's estimate is 1.3-fold (0.11 log units) below it; low and high end bracket the measured number.
By their numbers in this assay, from the lowest: compounds 3, 2, 1 and 4 (each within the scatter of the next).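

In this assay, for the compounds shown here, methyl on a saturated ring carbon of the three-membered ring gives a 1.3-fold higher number from compound 3 to compound 4 (0.12 log units; within the scatter), the first direct reading of a change at this ring carbon. Set against the two compounds without this ring, 1-methylcyclopropyl gives a 1.2-fold higher number from compound 2 to compound 4 (0.08 log units; within the scatter) and a 1.2-fold higher number from compound 1 to compound 4 (0.07 log units; within the scatter), so this side chain also stays unresolved from them. No available evidence accounts for the size of these steps.

Going by these compounds, whether ethyl or hydroxymethyl on this ring carbon would give a step beyond the scatter in this assay remains open.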